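A Second Methoxy on the Core of Compound 1

This account rests on a few compounds, and the source may have more. Where it says the series, first, only, none or still open, it means among the compounds named here.

Compound 1 `COc1ccc(C(=O)c2cc(OC)c(OC)c(OC)c2)cc1NC(=O)/C=C/c1ccc(F)cc1` stands lowest of the three measured compounds in a functional assay on PC-3 cells (Homo sapiens) for cytotoxicity, read by MTT assay, with a stated time of 72 h; a higher number here means a weaker inhibitor, a lower number a stronger inhibitor: compound 1 gives 3200 nM. Compound 2 `COc1ccc(C(=O)c2cc(OC)c(OC)c(OC)c2)cc1NC(=O)/C=C/c1ccc(F)c(F)c1` gives 8300 nM in this assay, and compound 3 `COc1ccc(C(=O)c2cc(OC)c(OC)c(OC)c2)cc1NC(=O)/C=C/c1ccc([N+](=O)[O-])cc1` gives 10400 nM. The steps shown move in one direction: a 2.6-fold higher number from compound 1 to compound 2 (0.41 log units; beyond the scatter) and a 3.3-fold higher number from compound 1 to compound 3 (0.51 log units; beyond the scatter), while a 1.3-fold higher number from compound 2 to compound 3 (0.10 log units; within the scatter).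

Compound 4 `COc1cc(C(=O)c2cc(OC)c(OC)c(OC)c2)cc(NC(=O)/C=C/c2ccc(F)cc2)c1OC` differs from compound 1 elsewhere: methoxy in place of hydrogen on an aromatic carbon. Among the compounds with values here, each of the measured steps alters the aryl group on the double-bonded chain, not the ring that carries the amide; none of them bears on this change, so the step from compound 1 to compound 4 has no direct precedent among the numbers here. With no guide in either direction, the expected step is a 1.3-fold higher number from compound 1 to compound 4 (0.10 log units; within the scatter), a number not expected to move beyond the scatter. Compound 4 is therefore estimated at 4000 nM in this assay, within a range from 1500 nM to 11000 nM.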

Compound 4, half-maximal inhibitory concentration: 4100 nM
The estimate for compound 4 lay 1.0-fold (0.01 log units) below the measured number, and the stated range covers the measured number.
By their numbers in this assay, from the lowest: compounds 1 and 4 (each within the scatter of the next); then compounds 2 and 3 (each within the scatter of the next).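

In this assay, methoxy in place of hydrogen on an aromatic carbon of the core of compound 1, ortho to a methoxy group and meta to a ((2-(4-fluorophenyl)ethenyl)carbonyl)amino group, gives a 1.3-fold higher number from compound 1 to compound 4 (0.11 log units; within the scatter) and so leaves the number within the scatter. This is the first step shown that changes the core rather than the aryl group on the double-bonded chain, and at this position the added methoxy brings no change that can be told from the scatter. No measurement shown offers an explanation for this result.

On these data alone, whether an amine, a hydroxyl or a longer alkoxy chain at this position would behave as methoxy does remains open. So does whether the added methoxy would give a similarly small step alongside the 3,4-difluorophenyl group of compound 2 or the 4-nitrophenyl group of compound 3.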